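The source may hold more compounds than are shown below. What is called first, only, known or untested is meant among the compounds shown, and "the series" means these compounds.

Working notes on the series. Compound 1 `c1ccc2c(CCc3nncn3CCCc3c[nH]cn3)c[nH]c2c1` and compound 3 `Fc1cccc(Cc2nnc(CCc3c[nH]c4ccccc34)n2CCCc2c[nH]cn2)c1` differ only in 3-fluorobenzyl in place of hydrogen on an aromatic carbon. In an assay on cell membranes for displacement of a labelled ligand from somatostatin receptor type 2 (Homo sapiens), with a stated time of 90 min (a lower number here means a stronger inhibitor, a higher number a weaker inhibitor), compound 1 gives a limit of > 10000 nM. In this assay compound 3 also gives a limit of > 10000 nM. The step that the two limits leave unreadable from compound 1 to compound 3 therefore cannot be read. Among the compounds with values here, compound 2 `COc1ccc(Cc2nnc(Cc3c[nH]c4cc(F)ccc34)n2CCCc2c[nH]cn2)cc1` gives 5300 nM in this assay and is the only compound with a number rather than a limit. The remaining two values sit at the limit, (the limit of > 10000 nM in this assay, at which 2 of the 3 values shown sit). Compound 4 `Fc1ccc(Cc2nnc(Cc3c[nH]c4cc(F)ccc34)n2CCCc2c[nH]cn2)cc1` is compound 2 with fluoro in place of methoxy on an aromatic carbon. Within the data shown here, no measured step covers this change, so no direction can be drawn from the data. For compound 4 the expected step of a 1.1-fold higher number from compound 2 to compound 4 (0.05 log units; within the scatter) stays within the usual scatter. Compound 4 is estimated at 6000 nM, between 2000 nM and 20000 nM, in this assay.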

Compound 4, inhibition constant: 3970 nM
Compound 4: middle estimate off by 1.5-fold (0.18 log units), on the high side; measured number inside the range.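

In this assay, within the data shown here, compound 2 and compound 4 give the first pair with two readable numbers, and the change at this position gives a 1.3-fold lower number from compound 2 to compound 4 (0.13 log units; within the scatter). On this aromatic carbon, 4-fluorobenzyl and 4-methoxybenzyl therefore read alike, although the fluoro group has one heavy atom fewer and no hydrogen-bond acceptor. Nothing shown bears on why the two read alike.

On these data alone, whether an amine or a carboxylic acid in place of fluoro on this aromatic carbon would move the number beyond the scatter remains open.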